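This account rests on a few compounds, and the source may have more. Where it says the series, first, only, none or still open, it means among the compounds named here.

Compounds measured so far:

Compound 1 `ClCc1cccc(Cn2cnc3ncnc(Cl)c32)c1` gives 6020 nM in a functional assay on HT-29 cells (Homo sapiens) for cytotoxicity, read by sulforhodamine B assay, with a stated time of 48 h; on this read-out higher numbers stand for lower toxicity in this test and lower numbers for higher toxicity in this test.
Compound 2 `ClCc1cccc(Cn2cnc3c(Cl)ncnc32)c1` gives only a limit of the assay, > 100000 nM, in this assay.
Compound 3 `ClCc1cccc(Cn2cnc3c(Cl)nc(Cl)nc32)c1` likewise gives only a limit of the assay, > 100000 nM, in this assay.

Compound 3 therefore stands at the upper edge of what this assay reports, with no number of its own; compound 2 sits at the same edge, and compound 1 is the only one of the three with a read value. Within the data shown here, the single measured step, a step that the two limits leave unreadable from compound 2 to compound 3, cannot be sized because both ends are limits (the limit of > 100000 nM in this assay, at which 2 of the 3 values shown sit).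

Compound 4 `Nc1nc(Cl)c2ncn(Cc3cccc(CCl)c3)c2n1` is the next one to be measured. It differs from compound 3 in that (amino in place of chloro on an aromatic carbon). Among the measured compounds shown here, no measured step bears directly on this change, and the only step is unreadable, so the direction and size of an at least 1.6-fold lower number from compound 3 to compound 4 (0.22 log units; that floor lies within the scatter) are expected only on the basis that compound 3 itself gave no number. Compound 4 is estimated at 60000 nM, within 15000 nM to 200000 nM, with a fair chance that this assay again returns only a limit.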

Compound 4, concentration lethal to 50% of the cells: 64600 nM
Estimate against measurement, compound 4: 1.1-fold (0.03 log units) below; low and high end bracket the measured number.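

With amino in place of chloro on an aromatic carbon between two ring nitrogen atoms, compound 4 gives a read number in this assay, 64600 nM, the first at this position in the series. The change shows an at least 1.5-fold lower number from compound 3 to compound 4 (0.18 log units; that floor lies within the scatter), and amino in place of hydrogen shows an at least 1.5-fold lower number from compound 2 to compound 4 (0.18 log units; that floor lies within the scatter); both floors lie within the scatter, so neither establishes a real change in toxicity. The true size of these steps stays unknown, and the step between compound 2 and compound 3 cannot be read, because these comparisons rest on: the limit of > 100000 nM in this assay, at which 2 of the 4 values shown sit.

On these data alone, whether a hydroxyl or a methylamino group at this position would also give a read number remains open. Among these compounds, also open is how an amino group at this position would read on the core of compound 1, the only other compound with a read number.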